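Swapping a Methyl Ester for a Benzyl Ester

The source may hold more compounds than are shown below. What is called first, only, known or untested is meant among the compounds shown, and "the series" means these compounds.

Compound 1 `C=C1CC[C@H]2[C@@](C)(CC[C@@H](OC(C)=O)[C@@]2(C)C(=O)OC)[C@@H]1/C=C/C1=CCOC1=O` and compound 2 `C=C1CC[C@H]2[C@@](C)(CC[C@@H](OC(C)=O)[C@@]2(C)C(=O)OCc2ccccc2)[C@@H]1/C=C/C1=CCOC1=O` share one core; compound 3 `C=C1CC[C@H]2[C@@](C)(CC[C@@H](O)[C@@]2(C)C(=O)OC)[C@@H]1C/C=C1\C=COC1=O` and compound 4 `C=C1CC[C@H]2[C@@](C)(CC[C@@H](O)[C@@]2(C)C(=O)OCc2ccccc2)[C@@H]1C/C=C1\C=COC1=O` share another, and the difference between the two cores is not broken down here. In a functional assay on NIH3T3 cells (Mus musculus) for inhibition, read by MTT assay, with a stated time of 72 h (a higher number here means a weaker inhibitor, a lower number a stronger inhibitor), compound 1 gives 32300 nM, and compound 2 gives 52700 nM. The change between them, (phenyl in place of hydrogen on a saturated chain carbon bound to an oxygen next to a carbonyl group), produced a 1.6-fold higher number from compound 1 to compound 2 (0.21 log units; within the scatter). In this assay compound 3 gives 177000 nM, a number beyond the scatter from both of the others. Compound 4 carries the same change on the core of compound 3: phenyl in place of hydrogen on a saturated chain carbon bound to an oxygen next to a carbonyl group. Resting on a 1.6-fold higher number from compound 1 to compound 2 (0.21 log units; within the scatter), which stayed within the scatter, a similarly small step is expected here: a 1.4-fold higher number from compound 3 to compound 4 (0.13 log units; within the scatter). Compound 4 is therefore estimated at 240000 nM, with the expected range running from 100000 nM to 550000 nM.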

Compound 4, half-maximal inhibitory concentration: 177000 nM
The estimate for compound 4 lay 1.4-fold (0.13 log units) above the measured number; low and high end bracket the measured number.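

In this assay, moving from methyl to benzyl on the second core gave no change at the digits printed from compound 3 to compound 4 (within the scatter). Set beside the earlier step, the change behaves alike on both cores: the same change on two cores in this assay, a 1.6-fold higher number (0.21 log units; within the scatter) from compound 1 to compound 2 and no change at the digits printed (within the scatter) from compound 3 to compound 4, 1.6-fold (0.21 log units) apart, within the scatter of two such steps. This shows that on these two cores the swap leaves the number within the scatter, but it does not show that the same would hold on any other core, and it says nothing about why the step is so small.

The compounds shown leave open what a longer chain or an amine in place of the benzyl would do, or a carboxylic acid in place of the ester. They also leave open which part of the difference between the two cores separates their numbers.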